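The source may hold more compounds than are shown below. What is called first, only, known or untested is meant among the compounds shown, and "the series" means these compounds.

Working notes on the series. In a functional assay on RAW264.7 cells (Mus musculus) for inhibition, with stated times of 2 h and 24 h (a higher number here means a weaker inhibitor, a lower number a stronger inhibitor), compound 1 (`O=C1c2cc(O)cc(O)c2[C@@H](c2ccc(O)cc2)[C@@H]1c1cc(O)cc(O)c1`) gives > 200000 nM, which is a limit of the assay and not a number. Compound 2 (`COc1ccc([C@@H]2c3c(OC)cc(OC)cc3C(=O)[C@H]2c2cc(OC)cc(OC)c2)cc1`) gives > 200000 nM, also a limit and not a number, so compound 2 has no numeric value in this assay.

Compound 3 (`COc1cc(OC)cc([C@@H]2C(=O)c3cc(OC)cc(OC)c3[C@H]2c2ccccc2)c1`) has hydrogen in place of methoxy on an aromatic carbon, para to a large group, so that 4-methoxyphenyl becomes phenyl: hydrogen in place of methoxy on an aromatic carbon. Among the measured compounds shown here, no measured step gives the size of this change. As compound 2 stands at > 200000 nM, a limit, no step beyond the scatter is expected in this assay, in either direction, and another limit is the likeliest report. The estimated a number no higher from compound 2 to compound 3 (the limit leaves the size open) is therefore small. For compound 3 the expected value is 200000 nM, with an estimated range of 40000 nM to 400000 nM.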

Compound 3, half-maximal inhibitory concentration: 27100 nM
Compound 3: middle estimate off by 7.4-fold (0.87 log units), on the high side; measured number outside the range, below it.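

In this assay, among the compounds shown here, the change from 4-methoxyphenyl to phenyl gives an at least 7.3-fold lower number from compound 2 to compound 3 (0.86 log units; beyond the scatter), and compound 3 provides the first value that is a number and not a limit. The position on the aromatic carbon para to a large group is therefore one where this assay registers a change, with hydrogen giving the lower number than methoxy in this single pair. The step has a floor but no known upper size, as its starting point is a limit: the limit of > 200000 nM in this assay, at which 2 of the 3 values shown sit.

On these data alone, it remains open how an amine, a carboxylic acid or a longer chain such as butoxy would read at this position. Also open, as far as these compounds go, is what the remaining methoxy groups of compound 3 contribute to its value.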